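A few compounds are considered here, and "the series" means these few. Any claim that something is new, unique, unknown or untested is made for them only; others in the source may bear on it.

Measured so far in an assay on HEK293 cells for inhibition of N-acylethanolamine-hydrolyzing acid amidase (Homo sapiens), read by fluorescence, with stated times of 10 min and 50 min; a lower number here means a stronger inhibitor, a higher number a weaker inhibitor:
- compound 1 `CCCCCCCON1C(=O)[C@@H](NC(=O)OCCCCC2CCCCC2)[C@@H]1C` gives 2230 nM
- compound 2 `C[C@H]1[C@H](NC(=O)OCCCCC2CCCCC2)C(=O)N1OCCCS(C)(=O)=O` gives 49 nM
- compound 3 `C[C@H]1[C@H](NC(=O)OCCCCC2CCCCC2)C(=O)N1Oc1ccc(Oc2ccccc2)cc1` gives 48 nM

Compound 2 stands second highest of the three numbers. Its nearest neighbour is compound 3, whose number lies within the scatter of that of compound 2, so the two cannot be ranked against each other. Among the compounds with values here, its furthest neighbour is compound 1, and the only single-place step measured runs between these two: a 46-fold lower number from compound 1 to compound 2 (1.66 log units; beyond the scatter), a large step, with methylsulfonyl in place of butyl on a saturated chain carbon.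

Compound 4 `C[C@H]1[C@H](NC(=O)OCCCCC2CCCCC2)C(=O)N1Oc1ccccc1S(C)(=O)=O` has not yet been measured in this assay. It differs from compound 2 in one place: 2-(methylsulfonyl)phenyl in place of 3-(methylsulfonyl)propyl on an oxygen

Within the data shown here, no measured step changes the group on the oxygen from a chain to an aromatic ring while keeping the methylsulfonyl, so the step from compound 1 to compound 2 bears on it only in that the methylsulfonyl is retained in compound 4. What the values of compound 2 and compound 3 show is that a 3-(methylsulfonyl)propyl and an aromatic group on this oxygen give numbers within the scatter of each other. On that basis the change is expected to give no step beyond the scatter, a 1.1-fold higher number from compound 2 to compound 4 (0.05 log units; within the scatter), with some uncertainty in both directions. Compound 4 is therefore estimated at 55 nM, within the range 18 nM to 170 nM.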

Compound 4, half-maximal inhibitory concentration: 6 nM
The estimate for compound 4 lay 9.2-fold (0.96 log units) above the measured number; measured number outside the range, below it.
By their numbers in this assay, from the lowest: compound 4; then compounds 3 and 2 (each within the scatter of the next); then compound 1.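

In this assay, the step from a chain to an aromatic ring on this oxygen, with the methylsulfonyl kept, is an 8.2-fold lower number from compound 2 to compound 4 (0.91 log units; beyond the scatter), so the oxygen substituent still separates compounds that carry a methylsulfonyl group. An aromatic ring alone does not account for this result: compound 3, with a phenoxyphenyl group and no methylsulfonyl, gives 48 nM, which lies within the scatter of compound 2, whereas compound 4 gives 6 nM. Measured against the plain heptyl group, 2-(methylsulfonyl)phenyl gives a 370-fold lower number from compound 1 to compound 4 (2.57 log units; beyond the scatter), the widest step yet seen at this position.

Nothing available accounts for the difference between the 2-(methylsulfonyl)phenyl and 3-(methylsulfonyl)propyl groups. The compounds shown also leave open how much of the result belongs to the methylsulfonyl and how much to the phenyl ring carrying it, a question that a plain phenyl group, or a phenyl group with a carboxylic acid in place of the methylsulfonyl, would address.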